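The compounds below may be only part of what the source reports. "The series", "measured", "known", "first", "only" and "open" are said of these compounds alone.

Working notes on the series. Compound 1 `CCOC(=O)NC(=O)NC1=CS(=O)(=O)O[C@@]12[C@@H](CO[Si](C)(C)C(C)(C)C)O[C@@H](n1cc(C)c(=O)n(C)c1=O)[C@@H]2O[Si](C)(C)C(C)(C)C` carries an (ethoxycarbonyl)carbamoyl group on the amine nitrogen of the shared core; in a functional assay on HEL cells (Homo sapiens) for cytotoxicity, read by microscopy (on this read-out lower numbers stand for higher toxicity in this test and higher numbers for lower toxicity in this test), compound 1 gives 16000 nM. Compound 2 `COC(=O)C(=O)CNC1=CS(=O)(=O)O[C@@]12[C@@H](CO[Si](C)(C)C(C)(C)C)O[C@@H](n1cc(C)c(=O)n(C)c1=O)[C@@H]2O[Si](C)(C)C(C)(C)C` carries a ((methoxycarbonyl)carbonyl)methyl group at the same position. In this assay compound 2 reaches only a limit, > 400000 nM, so no number is known for it. Going by the values given here, the single measured step, an at least 25-fold higher number from compound 1 to compound 2 (1.39 log units; beyond the scatter), thus rests on that limit of > 400000 nM in this assay, at which 1 of the 2 values shown sits, and gives only a lower bound for the size of the change.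

Compound 3 `Cc1cn([C@@H]2O[C@H](CO[Si](C)(C)C(C)(C)C)[C@@]3(OS(=O)(=O)C=C3NC(=O)NC(=O)c3ccccc3)[C@H]2O[Si](C)(C)C(C)(C)C)c(=O)n(C)c1=O` is the next member. The change from compound 2 is benzoylcarbamoyl in place of ((methoxycarbonyl)carbonyl)methyl on an amine nitrogen. Among the compounds with values here, the group that enters shares its carbamoyl part with the group of compound 1, whereas the group that leaves is the one that took compound 2 beyond the limit; no measured step covers the benzoyl part itself. Within the data shown here, the only step that bears on this is the one from compound 1 to compound 2, and it ran toward a higher number on removing the carbamoyl group; restoring a carbamoyl group is expected to reverse it, so a step of an at least 16-fold lower number from compound 2 to compound 3 (1.20 log units; beyond the scatter) is expected for compound 3. Compound 3 is therefore estimated at 25000 nM, with a range from 6000 nM to 150000 nM.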

Compound 3, minimum cytotoxic concentration: >= 80000 nM
Compound 3 gave a limit, no number; the forecaster's own chance of this, stated with the estimate: 30%; middle value at least 3.2-fold (0.50 log units) from the limit.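

With the carbamoyl part kept on the amine nitrogen, phenyl in place of ethoxy on the carbonyl carbon gives an at least 5.0-fold higher number from compound 1 to compound 3 (0.69 log units; beyond the scatter) in this assay. The earlier step exchanged the whole group at this position, whereas this one shows that the read-out also moves when only the end of the group changes, so the carbamoyl part alone does not hold the number at the level of compound 1. This step is only a lower bound for the size of the change, and the step between compound 2 and compound 3 cannot be read: the limit of >= 80000 nM in this assay, at which 1 of the 3 values shown sits.

Still open, going by these compounds, is how far the true number of compound 3 lies beyond its limit, and so how the benzoylcarbamoyl and ((methoxycarbonyl)carbonyl)methyl groups rank against each other on this amine nitrogen. Also open, on these data alone, is whether a dimethylamino group or a longer alkyl chain in place of phenyl on the same carbonyl carbon would give a number in this assay rather than another limit, which would show how the read-out depends on the end of the group.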